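Replacing the 2-isopropylphenyl group of a urea on a shared core

The source may hold more compounds than are shown below. What is called first, only, known or untested is meant among the compounds shown, and "the series" means these compounds.

Of the compounds shown here, three on a shared core have been measured in a functional assay on Shh Light II cells (Mus musculus) for inhibition, read by a luciferase reporter; on this read-out lower numbers stand for stronger inhibition and higher numbers for weaker inhibition. Compound 1 `O=C(CC1CCCCCC1)N1CCC(c2nc(-c3ccc4ccccc4n3)no2)CC1` gives 840 nM. Compound 2 `CC(C)c1ccccc1NC(=O)N1CCC(c2nc(-c3ccc4ccccc4n3)no2)CC1` gives 480 nM, and compound 3 `O=C(NC1CC[S+]([O-])CC1)N1CCC(c2nc(-c3ccc4ccccc4n3)no2)CC1` gives 850 nM. Compound 2 sits at one end of these three numbers, but its neighbours are close: a 1.8-fold lower number from compound 1 to compound 2 (0.24 log units; within the scatter) and a 1.8-fold higher number from compound 2 to compound 3 (0.25 log units; within the scatter), both within the scatter, so the three cannot be told apart.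

Compound 4 `O=C(Nc1cccnc1Cl)N1CCC(c2nc(-c3ccc4ccccc4n3)no2)CC1` differs from compound 2 in one place: 2-chloropyridin-3-yl in place of 2-isopropylphenyl on an amide-type nitrogen. Going by the values given here, two measured steps bear on this. The step from compound 2 to compound 3 also replaced the six-membered aromatic ring of carbon only on the amide-type nitrogen, there by a six-membered non-aromatic ring with a hetero atom, and gave a 1.8-fold higher number from compound 2 to compound 3 (0.25 log units; within the scatter). The step from compound 1 to compound 2 changed the group on the carbonyl carbon and gave a 1.8-fold lower number from compound 1 to compound 2 (0.24 log units; within the scatter). Among the compounds with values here, neither step went beyond the scatter, and no other measured pair speaks to a ring with a hetero atom and a chlorine in this place. He therefore expects no step beyond the scatter in this assay. Compound 4 is estimated at 600 nM, in a range from 250 nM to 1500 nM. That estimate is expected to mean a 1.3-fold higher number from compound 2 to compound 4 (0.10 log units; within the scatter).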

Compound 4, half-maximal inhibitory concentration: 1600 nM
The estimate for compound 4 lay 2.7-fold (0.43 log units) below the measured number; the measured number lies above the stated range.
By their numbers in this assay, from the lowest: compounds 2, 1, 3 and 4 (each within the scatter of the next, the first and the last beyond it).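

In this assay, going by these compounds alone, this is the first replacement on the amide-type nitrogen to go beyond the scatter, with a 3.3-fold higher number from compound 2 to compound 4 (0.52 log units; beyond the scatter), so 2-chloropyridin-3-yl does not match 2-isopropylphenyl here, although the step is only modest. That separation holds for this one pair alone: a 1.9-fold higher number from compound 3 to compound 4 (0.27 log units; within the scatter) and a 1.9-fold higher number from compound 1 to compound 4 (0.28 log units; within the scatter) both lie within the scatter, so compound 4 cannot be told apart from either of those two compounds. Nothing available here accounts for the step.

The compounds shown leave open whether the step follows the ring nitrogen or the chlorine that takes the place of the isopropyl group, as both enter together; a 2-chlorophenyl or a 2-isopropylpyridin-3-yl group on this nitrogen would separate the two. They also leave open whether other groups in this place, such as an unsubstituted phenyl, a 2-methylphenyl or a 2-methoxyphenyl, would stay within the scatter of compound 2 or fall with compound 4.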